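This account rests on a few compounds, and the source may have more. Where it says the series, first, only, none or still open, it means among the compounds named here.

Compound 1 `CC[C@@H](Nc1c(Nc2cccc(C(=O)N(C)C)c2O)c(=O)c1=O)c1cc(C)cs1` is the starting point. Among the measured compounds shown here, in an assay on CHO cells for displacement of a labelled ligand from C-X-C chemokine receptor type 1 (Homo sapiens) (a higher number here means a weaker inhibitor, a lower number a stronger inhibitor), compound 1 gives 24 nM, the second highest of the three numbers measured so far. Compound 2 `CC[C@@H](Nc1c(Nc2cccc(C(=O)N(C)C)c2O)c(=O)c1=O)c1cc(C)co1` gives 9 nM, and compound 3 `CCCCc1coc([C@@H](CC)Nc2c(Nc3cccc(C(=O)N(C)C)c3O)c(=O)c2=O)c1` gives 34 nM. The new compound 4 `CCC(C)c1coc([C@@H](CC)Nc2c(Nc3cccc(C(=O)N(C)C)c3O)c(=O)c2=O)c1` differs from compound 1 in one place: 4-(sec-butyl)furan-2-yl in place of 4-methylthiophen-2-yl on a saturated chain carbon bound to a nitrogen on an aromatic ring and a saturated chain carbon. For the measured compounds named here, two measured steps bear on this change. The first, a 2.7-fold lower number from compound 1 to compound 2 (0.43 log units; beyond the scatter), puts 4-methylfuran-2-yl in place of 4-methylthiophen-2-yl with nothing else altered. The second, a 3.8-fold higher number from compound 2 to compound 3 (0.58 log units; beyond the scatter), adds propyl in place of hydrogen on a saturated chain carbon bound to an aromatic carbon, lengthening the chain on the same ring. Compound 4 combines both kinds of change, a 4-(sec-butyl)furan-2-yl group, so the two effects are expected to pull in opposite directions and largely cancel, much as the direct comparison a 1.4-fold higher number from compound 1 to compound 3 (0.15 log units; within the scatter) already shows. Compound 4 is therefore expected to land close to compound 1, with the step of a 1.0-fold higher number from compound 1 to compound 4 (0.02 log units; within the scatter) staying within the scatter. The estimate for compound 4 is 25 nM, with a range from 8 nM to 70 nM.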

Compound 4, inhibition constant: 7.6 nM
Compound 4: the middle estimate sits 3.3-fold (0.52 log units) above what was measured, outside the stated range (below it).
By their numbers in this assay, from the lowest: compounds 4 and 2 (each within the scatter of the next); then compounds 1 and 3 (each within the scatter of the next).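

In this assay, the butyl result does not hold for every alkyl group at this place on the furan: sec-butyl in place of butyl gives (a 4.5-fold lower number from compound 3 to compound 4 (0.65 log units; beyond the scatter)), a clear gain from a change of chain shape alone. Sec-butyl in place of methyl gives (a 1.2-fold lower number from compound 2 to compound 4 (0.07 log units; within the scatter)), which stays within the scatter, so the loss seen on going to butyl does not appear with sec-butyl. The 4-(sec-butyl)furan-2-yl group also beats the 4-methylthiophen-2-yl group of the starting compound, with (a 3.2-fold lower number from compound 1 to compound 4 (0.50 log units; beyond the scatter)) lying beyond the scatter.

As far as these compounds go, it remains open whether other branched groups, such as isopropyl or tert-butyl, or a ring such as cyclopropyl, would match sec-butyl here, and whether sec-butyl on the thiophene would do the same. Nothing measured here accounts for these differences.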